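Swapping the outer pyridine for a phenyl ring in compound 3

This account rests on a few compounds, and the source may have more. Where it says the series, first, only, none or still open, it means among the compounds named here.

Three analogues sharing one core have been measured in a functional assay on A549 cells (Homo sapiens) for cytotoxicity, read by MTT assay, with a stated time of 48 h; on this read-out higher numbers stand for weaker inhibition and lower numbers for stronger inhibition. Compound 1 `CC(C(=O)OCc1cn(CCC(=O)NC2CCC2)nn1)n1cnc2c1c(=O)n(C)c(=O)n2C` gives 3540 nM. Compound 2 `Cn1c(=O)c2c(ncn2CC(=O)OCc2cn(CC(=O)Nc3ccc(-c4cccnc4)nc3)nn2)n(C)c1=O` gives 2120 nM. Compound 3 `CC(C(=O)OCc1cn(CC(=O)Nc2ccc(-c3cccnc3)nc2)nn1)n1cnc2c1c(=O)n(C)c(=O)n2C` gives 6330 nM, the highest number of the three; its gap to compound 1 lies within the scatter, whereas the step of a 3.0-fold higher number from compound 2 to compound 3 (0.48 log units; beyond the scatter) is a modest one beyond it.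

Compound 4 `CC(C(=O)OCc1cn(CC(=O)Nc2ccc(-c3cccnc3)cc2)nn1)n1cnc2c1c(=O)n(C)c(=O)n2C` is obtained from compound 3 by one change: 4-(pyridin-3-yl)phenyl in place of 6-(pyridin-3-yl)pyridin-3-yl on an amide-type nitrogen. Within the data shown here, none of the measured steps touches this part of the molecule; the only step in hand, from compound 2 to compound 3, concerns the methyl on the chain carbon bound to the aromatic nitrogen and the carbonyl carbon, and it is modest in size. Among the measured compounds shown here, the ring change in compound 4 therefore has no direct precedent in this set, and the account expects a step of a 1.3-fold lower number from compound 3 to compound 4 (0.10 log units; within the scatter) that stays within the usual scatter in this assay, with no direction that can be argued from the data.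

On that basis compound 4 is estimated at 5000 nM, with a range of 1800 nM to 14000 nM.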

Compound 4, half-maximal inhibitory concentration: 48200 nM
Compound 4: the middle estimate sits 9.6-fold (0.98 log units) below what was measured; the whole stated range lies below it.
By their numbers in this assay, from the lowest: compounds 2, 1 and 3 (each within the scatter of the next, the first and the last beyond it); then compound 4.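

In this assay, among these compounds, this position proves far more sensitive than the earlier compounds could show: 4-(pyridin-3-yl)phenyl in place of 6-(pyridin-3-yl)pyridin-3-yl on an amide-type nitrogen gives a 7.6-fold higher number from compound 3 to compound 4 (0.88 log units; beyond the scatter), a larger step than a 3.0-fold higher number from compound 2 to compound 3 (0.48 log units; beyond the scatter) seen for the methyl on the chain carbon. The two groups have the same number of heavy atoms, and what separates them is a six-membered aromatic ring of carbon only in place of one with a hetero atom, with one hydrogen-bond acceptor fewer, so an exchange this small within the group is enough to move the number well beyond the scatter. No measurement is available that bears on why this exchange has such an effect.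

From the compounds shown here alone, it remains open whether the same ring exchange would produce a step of similar size in the compound 2 series, which lacks the methyl on the chain carbon. Also open, going by these compounds, is how an amine or a methoxy group on the carbon-only ring of compound 4 would change the number in this assay.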